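The compounds below may be only part of what the source reports. "The series", "measured", "known", "first", "only" and "open" are said of these compounds alone.

Working notes on the series. Compound 1 `COc1ccc2nccc(CC[C@H]3CC[C@H](NCc4ccc(Cl)c(Cl)c4)CC3)c2c1` carries the shared core on one side and, on the other, an amine whose saturated chain carbon bears a 3,4-dichlorophenyl group. In an ADME assay on K562 cells (Homo sapiens) for antiproliferative activity (a lower number here means a stronger inhibitor, a higher number a weaker inhibitor), compound 1 gives "not determined" (no result reported), so it cannot be placed on the potency scale at all. Going by the values given here, the only measured member is compound 2 `COc1ccc2nccc(CC[C@H]3OC[C@H](NCc4ccc(Cl)c(Cl)c4)CO3)c2c1`, which differs from compound 1 in the saturated ring that joins the core to the amine; in this assay compound 2 gives 20000 nM, which marks it as a weak inhibitor. Among the compounds with values here, no step between compound 1 and compound 2 can be computed, since one end of it has no value; all that is known is the single reading for compound 2.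

Compound 3 `COc1ccc2nccc(CC[C@H]3CC[C@H](NCc4cc5c(cn4)OCCO5)CC3)c2c1` is reached from compound 1 by a group of 10 heavy atoms (7 carbon, 1 nitrogen, 2 oxygen; one six-membered non-aromatic ring with 2 hetero atoms, one six-membered aromatic ring with 1 hetero atom) in place of a group of 8 heavy atoms (6 carbon, 2 chlorine; one six-membered aromatic ring of carbon only), on a saturated chain carbon bound to an amine nitrogen. With no value for compound 1, the size and direction of this step cannot be read from data. Taking the weak reading of compound 2 as the only anchor, the step is expected to be small, within the scatter or slightly toward weaker inhibition. Compound 3 is therefore estimated at 15000 nM, with a range of 3000 nM to 60000 nM in this assay.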

Compound 3, half-maximal inhibitory concentration: 7500 nM
For compound 3 the middle estimate is 2.0-fold (0.30 log units) above the measured one, and the stated range covers the measured number.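

No new step can be read: in this assay compound 1 gives "not determined" (no result reported) and so the change to compound 3 has no size. Nothing at hand bears on the reading of compound 3. The compounds shown leave open how the 3,4-dichlorophenyl group and the group entering in compound 3 compare in potency on the shared core.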